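A few compounds are considered here, and "the series" means these few. Any claim that something is new, unique, unknown or untested is made for them only; others in the source may bear on it.

Of the compounds shown here, two from this series have so far been tested in a functional assay on DU-145 cells (Homo sapiens) for cytotoxicity, read by sulforhodamine B assay, with a stated time of 2 days, tested at 100 uM; on this read-out higher numbers stand for more inhibition at the one concentration tested (going by the name of the read-out) and lower numbers for less inhibition. Compound 1 `COc1cccc(-c2nc3c(-c4ccco4)n[nH]c3c(=O)n2NC(=O)c2cccnc2)c1` gives 30.1% in this assay, and compound 2 `O=C(Nn1c(-c2cccc([N+](=O)[O-])c2)nc2c(-c3ccco3)n[nH]c2c1=O)c1ccccc1` gives 16.1%. Compound 2 therefore stands lowest of the two numbers, and its nearest neighbour, compound 1, lies higher by more than the usual scatter.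

Compound 3 `COc1cccc(-c2nc3c(-c4ccco4)n[nH]c3c(=O)n2NC(=O)c2ccccc2)c1` has not yet been measured in this assay. It differs from compound 2 in one place: methoxy in place of nitro on an aromatic carbon. Going by the values given here, no pair of measured compounds differs in only this place, as compound 1 and compound 2 differ in two places. Even so, some lift seems plausible because compound 1 gives 30.1% while carrying the same 3-methoxyphenyl group. The step of a number 7.9 percentage points higher from compound 2 to compound 3 (within the scatter) is expected to be small and upward, possibly within the scatter. Compound 3 is expected to give 24% in this assay, within a range from 8% to 40%.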

Compound 3, a percentage reported as inhibition, at one concentration (the size of the read-out at that concentration, not a potency): 50.5%
The estimate for compound 3 lay 26.5 percentage points below the measured number; the measured number lies above the stated range.
By their numbers in this assay, from the lowest: compound 2; then compound 1; then compound 3.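

In this assay, going by these compounds alone, methoxy in place of nitro on the aromatic carbon gives a number 34.4 percentage points higher from compound 2 to compound 3 (beyond the scatter), the first reading of this change with nothing else altered, and it shows that this place on the ring strongly affects the number. With the 3-methoxyphenyl group held fixed, phenyl in place of pyridin-3-yl on the carbonyl carbon gives a number 20.4 percentage points higher from compound 1 to compound 3 (beyond the scatter), so this second place also matters, though the step is modest. No data here bear on the reason for either step.

The compounds shown leave open whether the rise is specific to methoxy or would also appear with an amine, a hydroxyl or a longer ethoxy chain in the same place. They also leave open whether the step from nitro to methoxy would hold with pyridin-3-yl on the carbonyl carbon.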